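Hydroxymethyl for trifluoromethyl at the low-clearance end

A few compounds are considered here, and "the series" means these few. Any claim that something is new, unique, unknown or untested is made for them only; others in the source may bear on it.

Two compounds frame the series in an ADME assay (liver) for metabolic stability, with Liver microsome (Rattus norvegicus) as the target, using microsomes and NADPH, with a stated time of 30 min, at 37 degrees C, tested at 1 uM; on this read-out higher numbers stand for fast clearance and lower numbers for slow clearance. Compound 1 (`COCC#Cc1cc(C(O)(C(F)(F)F)C(F)(F)F)cnc1-c1ccc(S(=O)(=O)c2ccc(N)nc2)cc1`) reads > 399 mL.min-1.g-1 as a limit of the assay, not a number. Compound 2 (`C[C@](O)(c1ccc(-c2ncc(S(=O)(=O)c3ccc(N)nc3)s2)c(Cl)c1)C(F)(F)F`) reads < 14 mL.min-1.g-1 and this too is only a limit. Compound 2 therefore stands at the slow-clearance end of the two values shown.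

Compound 3 (`C[C@@](O)(CO)c1ccc(-c2ncc(S(=O)(=O)c3ccc(N)nc3)s2)c(Cl)c1`) has hydroxymethyl in place of trifluoromethyl on a saturated chain carbon bound to an aromatic carbon, an oxygen on a saturated carbon and a saturated chain carbon. Going by the values given here, no measured pair shows this change, so the expectation rests on compound 2 with its limit of < 14 mL.min-1.g-1 as the starting point. A small rise or none beyond the usual scatter is expected in this assay and another limit is quite possible. The estimated step of a number no lower from compound 2 to compound 3 (the limit leaves the size open) is correspondingly modest. For compound 3 the estimate is 14 mL.min-1.g-1 with 7 mL.min-1.g-1 to 35 mL.min-1.g-1 as the expected range.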

Compound 3, intrinsic clearance in microsomes: < 14 mL.min-1.g-1
Compound 3 was reported as a limit; the forecaster's own chance of this, stated with the estimate: 55%; the middle value lies on the limit itself.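

In this assay, going by these compounds alone, compound 3 gives < 14 mL.min-1.g-1 as a limit and not a number, and compound 2 is also a limit, so no step between compound 2 and compound 3 can be read: the limit of < 14 mL.min-1.g-1 in this assay, at which 2 of the 3 values shown sit.

The compounds shown leave open whether hydroxymethyl in place of trifluoromethyl changes clearance at all.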